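One Stereocentre Inverted in a Weak Antiproliferative Series

This account rests on a few compounds, and the source may have more. Where it says the series, first, only, none or still open, it means among the compounds named here.

In a functional assay on HBL-100 cells (Homo sapiens) for antiproliferative activity, read by luminescence and CellTiter-Glo, with a stated time of 48 h (a higher number here means a weaker inhibitor, a lower number a stronger inhibitor), compound 1 (`O=C1C=CC[C@H]([C@@H]2C[C@H]2c2ccccc2)O1`) gives 43400 nM and compound 2 (`O=C1C=CC[C@H]([C@H]2C[C@@H]2c2ccccc2)O1`) gives 14400 nM, the lower of the two numbers available. Compound 3 (`O=C1CCC[C@H]([C@@H]2C[C@H]2c2ccccc2)O1`) gives only a limit, > 100000 nM. Compound 4 (`O=C1C=CC[C@@H]([C@H]2C[C@@H]2c2ccccc2)O1`) departs from compound 2 in this way: the two compounds have the same atoms and bonds and differ only in configuration as drawn: 1 of 3 stereo elements differ; a stereocentre at a saturated ring carbon is drawn R in compound 2 and S in compound 4. Among the compounds with values here, the one measured step that bears on this change, a 3.0-fold lower number from compound 1 to compound 2 (0.48 log units; beyond the scatter), also involves configuration alone, as the fact that compounds 1 and 2 differ only in the configuration as drawn shows, so a modest shift in this assay seems the likely scale, with no firm direction and perhaps a slight drift toward a higher number. The expected change is a 1.5-fold higher number from compound 2 to compound 4 (0.18 log units; within the scatter). For compound 4 the estimate is 22000 nM, with an expected range of 8000 nM to 60000 nM.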

Compound 4, half-maximal inhibitory concentration: 34900 nM
The estimate for compound 4 lay 1.6-fold (0.20 log units) below the measured number; measured number inside the range.
By their numbers in this assay, from the lowest: compound 2; then compounds 4 and 1 (each within the scatter of the next). At a limit, above all of these: compound 3.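

Inverting the single stereocentre is enough to move the number beyond the scatter in this assay: a 2.4-fold higher number from compound 2 to compound 4 (0.38 log units; beyond the scatter). Inverting all the stereocentres gives a 1.2-fold lower number from compound 1 to compound 4 (0.09 log units; within the scatter), so these mirror images cannot be told apart here. Among these three stereoisomers, the configuration of compound 2 alone stands apart, while the step to compound 4 shows that a single centre contributes to that difference.

The compounds shown leave open how the remaining configurations of the shared core would read. They also leave open whether an amine or a carboxylic acid on that core would shift the number.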